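This account rests on a few compounds, and the source may have more. Where it says the series, first, only, none or still open, it means among the compounds named here.

Compound 1 `CCCCCCCCc1ccc(OCC(=O)Cn2nnc(C)n2)cc1` gives 27 nM in an assay on microsomes from brain for inhibition of Fatty-acid amide hydrolase 1 (Rattus norvegicus), read by fluorescence and HPLC, with a stated time of 60 min; a higher number here means a weaker inhibitor, a lower number a stronger inhibitor. Within the data shown here, compound 2 `CCCCCCCCc1ccc(OCC(=O)Cn2nnc(-c3ccc(S(=O)(=O)N(C)C)cc3)n2)cc1` gives 590 nM in this assay, the higher of the two numbers, and the only measured step, a 22-fold higher number from compound 1 to compound 2 (1.34 log units; beyond the scatter), exchanges a methyl for a large group. Compound 3 `CCCCCCCCc1ccc(OCC(=O)Cn2nnc(-c3cccc(S(=O)(=O)N(C)C)c3)n2)cc1` differs from compound 2 by 3-(dimethylsulfamoyl)phenyl in place of 4-(dimethylsulfamoyl)phenyl on an aromatic carbon. Among the measured compounds shown here, no measured step moves the dimethylsulfamoyl group around the phenyl ring, so that step gives no direct guide, and the expectation is that compound 3 sits near compound 2 with a step of a 1.0-fold higher number from compound 2 to compound 3 (0.01 log units; within the scatter). The estimate for compound 3 is therefore 600 nM, within a range of 200 nM to 1800 nM.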

Compound 3, half-maximal inhibitory concentration: 420 nM
Beside the measured number, compound 3's estimate is 1.4-fold (0.15 log units) above it, within the range that was stated.
By their numbers in this assay, from the lowest: compound 1; then compounds 3 and 2 (each within the scatter of the next).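

The change from 4-(dimethylsulfamoyl)phenyl to 3-(dimethylsulfamoyl)phenyl on the aromatic carbon gives a 1.4-fold lower number from compound 2 to compound 3 (0.15 log units; within the scatter) in this assay, so these two placements of the dimethylsulfamoyl group are not told apart here. Against the methyl of compound 1, the new placement still gives a 16-fold higher number from compound 1 to compound 3 (1.19 log units; beyond the scatter), so the large step is not confined to the 4-(dimethylsulfamoyl)phenyl group. No measured evidence bears on the reason for this result. As far as these compounds go, what stays open is how a plain phenyl or an ethyl group at this position would compare with methyl, and whether a sulfamoyl group without its two methyl groups would read differently.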